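Series notes: compound 3 to compound 4

The source may hold more compounds than are shown below. What is called first, only, known or untested is meant among the compounds shown, and "the series" means these compounds.

Values in an ADME assay on BJ cells (Homo sapiens) for cytotoxicity, with a stated time of 72 h (a lower number here means that less compound is needed, a higher number that more compound is needed for the effect), follow.
- compound 1 `Nc1nc(-c2ccccc2)nn1-c1ncnc2cc(Cl)ccc12` gives > 50000 nM (a limit, not a number)
- compound 2 `Nc1cc2c(-n3nc(-c4ccccn4)nc3N)ncnc2cc1Cl` gives 27000 nM
- compound 3 `COc1cc2ncnc(-n3nc(-c4ccccn4)nc3N)c2cc1N` gives "not determined" (no result reported)

Compound 3 has no value in this assay, so its place among the compounds cannot be fixed. Only compound 2 provides an actual number. Compound 1 stands at a limit of the assay, (the limit of > 50000 nM in this assay, at which 1 of the 3 values shown sits).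

Compound 4 `COc1cc2ncnc(-n3nc(-c4ccccn4)nc3N)c2cc1OCCNC(=O)OC(C)(C)C` remains unmeasured. The change 2-((tert-butoxycarbonyl)amino)ethoxy in place of amino on an aromatic carbon puts 2-((tert-butoxycarbonyl)amino)ethoxy in place of amino on an aromatic carbon, ortho to a methoxy group.

Among the compounds with values here, no measured step is available to size this change, and compound 3 offers no starting value. No shift beyond the usual scatter, in either direction, is therefore expected from the high range set by compound 2 at 27000 nM. A result reported only as a limit would not be surprising.

For compound 4 the expected value in this assay is 30000 nM, with an estimated range from 12000 nM to 50000 nM.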

Compound 4, half-maximal effective concentration: > 15000 nM
Compound 4 gave a limit, no number; the forecaster's own chance of this, stated with the estimate: 45%; the middle value lies beyond the limit too.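

No step can be read between compound 3 and compound 4 in this assay. Compound 4 gives > 15000 nM, a limit and not a number. The compounds shown leave open how far 2-((tert-butoxycarbonyl)amino)ethoxy in place of amino shifts the half-maximal effective concentration.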